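Replacing 4-fluorophenyl with (naphthalen-2-yl)carbonyl on the sulfur chain

A few compounds are considered here, and "the series" means these few. Any claim that something is new, unique, unknown or untested is made for them only; others in the source may bear on it.

In a functional assay on HCT-116 cells (Homo sapiens) for inhibition, read by MTT assay, with a stated time of 48 h (on this read-out lower numbers stand for stronger inhibition and higher numbers for weaker inhibition), compound 1 `COc1ccc(-n2c(S)nnc2-c2cc(OC)c(OC)c(OC)c2)cc1` gives > 60000 nM as a limit of the assay and not a number. Compound 2 `CCSc1nnc(-c2cc(OC)c(OC)c(OC)c2)n1-c1ccc(OC)cc1` also gives > 60000 nM as a limit and not a number. Within the data shown here, compound 3 `COc1ccc(-n2c(SCc3ccc(F)cc3)nnc2-c2cc(OC)c(OC)c(OC)c2)cc1` gives 38700 nM as the only true number in the set. The change to compound 4 `COc1ccc(-n2c(SCC(=O)c3ccc4ccccc4c3)nnc2-c2cc(OC)c(OC)c(OC)c2)cc1` is (naphthalen-2-yl)carbonyl in place of 4-fluorophenyl on a saturated chain carbon bound to a sulfur and it falls on a saturated chain carbon bound to a sulfur. Among the measured compounds shown here, two measured steps bear on this: an at least 1.5-fold lower number from compound 2 to compound 3 (0.19 log units; that floor lies within the scatter) at that same place and an at least 1.5-fold lower number from compound 1 to compound 3 (0.19 log units; that floor lies within the scatter) on the same sulfur. Both are floors only, so a modest further fall in the number is expected and the range stays wide. The expected result is a 4.8-fold lower number from compound 3 to compound 4 (0.68 log units; beyond the scatter) as an estimated step. For compound 4 the estimate is 8000 nM and the value is expected between 500 nM and 60000 nM on this reasoning.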

Compound 4, half-maximal inhibitory concentration: > 60000 nM
Compound 4: a limit, no number; the forecaster's own chance of this, stated with the estimate: 15%; at least 7.5-fold (0.87 log units) between middle value and limit.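

In this assay, compound 4 gives only a limit of the assay and not a number, so (naphthalen-2-yl)carbonyl on a saturated chain carbon bound to a sulfur does not yield a measurable value here. The change from 4-fluorophenyl gives an at least 1.5-fold higher number from compound 3 to compound 4 (0.19 log units; that floor lies within the scatter), while the steps between compounds that both sit at the limit cannot be read. Compound 3 thus remains the only compound with a true number, and the others share one ceiling: the limit of > 60000 nM in this assay, at which 3 of the 4 values shown sit.

The compounds shown leave open how far the value of compound 4 lies from that limit. They also leave open whether a plain benzyl, an amine or a carboxylic acid on the sulfur chain would give a true number.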